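A methyl on the benzoyl ring of compound 2

The compounds below may be only part of what the source reports. "The series", "measured", "known", "first", "only" and "open" are said of these compounds alone.

Compound 1, `C=CCSc1nnc(-c2cc(OC)c(OC)c(OC)c2)n1N1C(=O)c2ccccc2C1=O`, reaches only a limit of > 200000 nM in a functional assay on HepG2 cells (Homo sapiens) for cytotoxicity, read by MTT assay, with a stated time of 48 h; a lower number here means a stronger inhibitor, a higher number a weaker inhibitor.
Compound 2, `COc1cc(-c2nnc(SCC(=O)c3ccccc3)n2N2C(=O)c3ccccc3C2=O)cc(OC)c1OC`, gives 171000 nM in this assay.

For the measured compounds named here, compound 2 holds the only number among the two values shown; the value of compound 1 is a limit and not a number. Going by the values given here, the single measured step, benzoyl in place of vinyl on a saturated chain carbon bound to a sulfur, runs an at least 1.1-fold lower number from compound 1 to compound 2 (0.06 log units; that floor lies within the scatter), and its floor rests on (the limit of > 200000 nM in this assay, at which 1 of the 2 values shown sits).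

Compound 3, `COc1cc(-c2nnc(SCC(=O)c3ccccc3C)n2N2C(=O)c3ccccc3C2=O)cc(OC)c1OC`, differs from compound 2 by methyl in place of hydrogen on an aromatic carbon. No measured step touches this aromatic ring; the only step shown changes the group on the sulfur-bound chain and is itself within the scatter. There is therefore nothing to draw on beyond the position of compound 2 itself, and no shift beyond the scatter is expected in this assay in either direction. Compound 3 is accordingly estimated to give 150000 nM in this assay, between 60000 nM and 320000 nM, a step of a 1.1-fold lower number from compound 2 to compound 3 (0.06 log units; within the scatter) that is expected to stay inside the scatter.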

Compound 3, half-maximal inhibitory concentration: > 200000 nM
Compound 3 ended at the assay's limit (the forecaster's own chance of this, stated with the estimate: 40%); middle value at least 1.3-fold (0.12 log units) from the limit.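

Methyl in place of hydrogen on an aromatic carbon of the benzoyl ring, ortho to a large group, gives an at least 1.1-fold higher number from compound 2 to compound 3 (0.06 log units; that floor lies within the scatter), and this is the only reading on this ring, where the earlier compounds offered none. As far as these compounds go, for compound 3, > 200000 nM in this assay is a limit of the assay and not a number, so the true size of the methyl step remains unknown. The step between compound 1 and compound 3 cannot be read, because both compounds end at the same limit, which leaves compound 2 as the only one of the three with a number: the limit of > 200000 nM in this assay, at which 2 of the 3 values shown sit.

The compounds shown leave open whether any other group on this ring, such as an amine, a fluorine or a carboxylic acid, would give a number clearly lower than that of compound 2 in this assay. They also leave open whether a methyl on another carbon of the ring, or a longer chain in its place, would give a readable number rather than a limit.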